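This account rests on a few compounds, and the source may have more. Where it says the series, first, only, none or still open, it means among the compounds named here.

Working notes on the series. In an assay on CHO cells for displacement of a labelled ligand from Orexin receptor type 2 (Homo sapiens) (a higher number here means a weaker inhibitor, a lower number a stronger inhibitor), compound 2 `Cn1c(CCC(=O)N2CCC[C@H]2C(=O)Nc2ccccc2-c2ccccc2)nc2ccccc21` gives 0.8 nM and holds the lowest of the two numbers measured; compound 1 `COc1ccccc1-c1ccccc1NC(=O)[C@@H]1CCCN1C(=O)CCc1nc2ccccc2[nH]1` gives 2 nM in this assay, a higher number by a margin beyond the scatter. Compound 1 also differs from compound 2 in the biphenyl part, so no single change is isolated there. Compound 3 `O=C(Nc1ccccc1-c1ccccc1)[C@@H]1CCCN1C(=O)CCc1nc2ccccc2[nH]1` differs from compound 2 only by hydrogen in place of methyl on an aromatic nitrogen. Within the data shown here, with no clean step of this kind on record, a step of a 1.9-fold higher number from compound 2 to compound 3 (0.27 log units; within the scatter) is expected, at most a slight weakening, possibly none beyond the scatter. For compound 3 an estimated 1.5 nM, within 0.5 nM to 4 nM, is expected.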

Compound 3, inhibition constant: 6 nM
The estimate for compound 3 lay 4.0-fold (0.60 log units) below the measured number; the whole stated range lies below it.
By their numbers in this assay, from the lowest: compound 2; then compound 1; then compound 3.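

In this assay, the methyl on the aromatic nitrogen matters: going from 1-methyl-1H-benzimidazol-2-yl to 1H-benzimidazol-2-yl gives a 7.5-fold higher number from compound 2 to compound 3 (0.88 log units; beyond the scatter) in this series. Where that nitrogen bears hydrogen, the methoxy on an aromatic carbon also matters, with hydrogen in its place giving a 3.0-fold higher number from compound 1 to compound 3 (0.48 log units; beyond the scatter) on the same scale. No measurement on hand accounts for either step. The compounds shown do not tell whether ethyl on that nitrogen would keep the lower number, or whether methyl and methoxy together would go lower than methyl alone.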